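Bromo to aryl swaps at the imidazopyrazine position, growth inhibition

This account rests on a few compounds, and the source may have more. Where it says the series, first, only, none or still open, it means among the compounds named here.

Compound 1 `Brc1cn2ccnc2c(-c2ccc3ncn(C4CCCCC4)c3c2)n1` carries a bromo group on the shared core; in a functional assay on KM12 cells (Homo sapiens) for inhibition, read by sulforhodamine B assay, with a stated time of 48 h, tested at 10 uM (on this read-out higher numbers stand for more inhibition at the one concentration tested (going by the name of the read-out) and lower numbers for less inhibition), compound 1 gives 67.7%. Compound 2 `c1cn2cc(-c3ccsc3)nc(-c3ccc4ncn(C5CCCCC5)c4c3)c2n1` carries thiophen-3-yl at the same place, and in this assay compound 2 gives 15.4%. Going by the values given here, this is the lower of the two numbers measured so far: the step of a number 52.3 percentage points lower from compound 1 to compound 2 (beyond the scatter) is the only one recorded. Compound 3 `CC(=O)c1ccc(-c2cn3ccnc3c(-c3ccc4ncn(C5CCCCC5)c4c3)n2)cc1` differs from compound 2 by 4-acetylphenyl in place of thiophen-3-yl on an aromatic carbon. Among the compounds with values here, no measured step exchanges one aromatic group for another at this position, so the single step from compound 1 to compound 2 bears on the present change only loosely, in that an aromatic group in place of bromo went with a large fall. Compound 3 keeps an aromatic group there, so a number near that of compound 2 is expected, with a number 9.6 percentage points higher from compound 2 to compound 3 (within the scatter) as the expected step. For compound 3 the estimate is 25%, within 5% to 55%.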

Compound 3, a percentage reported as inhibition, at one concentration (the size of the read-out at that concentration, not a potency): 11.7%
Estimate against measurement, compound 3: 13.3 percentage points above; low and high end bracket the measured number.
By their numbers in this assay, from the lowest: compounds 3 and 2 (each within the scatter of the next); then compound 1.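

In this assay, going by these compounds alone, the exchange of thiophen-3-yl for 4-acetylphenyl gives a number 3.7 percentage points lower from compound 2 to compound 3 (within the scatter) as the first aromatic-for-aromatic comparison at this position, even though the entering group has a six-membered carbon ring and a double bond outside the ring. Replacing bromo with 4-acetylphenyl gives a number 56 percentage points lower from compound 1 to compound 3 (beyond the scatter) and so shows that the large fall seen with thiophen-3-yl also occurs with a second aromatic group, a pattern that rests on compound 2 and compound 3 alone. No supporting data bear on the reason for this fall.

Still open, on these data alone, is whether the fall goes with aromatic groups as such or also with non-aromatic replacements for bromo. An amine such as morpholine or a short alkyl chain such as ethyl at this position would separate those two readings.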